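A Carbamoyl Group Replaces an Ester Chain

The source may hold more compounds than are shown below. What is called first, only, known or untested is meant among the compounds shown, and "the series" means these compounds.

Measured compounds:
Compound 1 `CCNC(=O)c1noc(-c2cc(C(C)C)c(O)cc2O)c1-c1cc(COCC(=O)OC)no1` — "not determined" (no result reported)
Compound 2 `C=CNCc1cc(-c2c(C(=O)NCC)noc2-c2cc(C(C)C)c(O)cc2O)on1` — 43 nM
Compound 3 `CCNC(=O)c1noc(-c2cc(C(C)C)c(O)cc2O)c1-c1cc(CN(C)C)no1` — 31 nM

On these data alone, in a functional assay on A2780 cells (Homo sapiens) for inhibition (a lower number here means a stronger inhibitor, a higher number a weaker inhibitor), compound 1 has no reported number, so its standing among the three is unknown. Compound 4 `CCNC(=O)c1noc(-c2cc(C(C)C)c(O)cc2O)c1-c1cc(C(N)=O)no1` differs from compound 1 by one exchange: carbamoyl in place of ((methoxycarbonyl)methoxy)methyl on an aromatic carbon. Going by the values given here, the only measured step, a 1.4-fold lower number from compound 2 to compound 3 (0.14 log units; within the scatter), concerns a different kind of change on a saturated chain carbon and does not bear directly on this exchange. What the data do show is that compound 2, carrying a small group on the same five-membered ring, gives 43 nM in this assay, and compound 3, carrying its own small group there, gives 31 nM, values within the scatter of each other. Compound 4 is expected to fall near that level, estimated at 40 nM with a range of 12 nM to 130 nM.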

Compound 4, half-maximal inhibitory concentration: 15 nM
Compound 4: middle estimate off by 2.7-fold (0.43 log units), on the high side; measured number inside the range.
By their numbers in this assay, from the lowest: compound 4; then compounds 3 and 2 (each within the scatter of the next).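

In this assay placing carbamoyl on this aromatic carbon gives a 2.1-fold lower number from compound 3 to compound 4 (0.32 log units; beyond the scatter) and also a 2.9-fold lower number from compound 2 to compound 4 (0.46 log units; beyond the scatter) and both modest steps lie beyond the scatter. Going by these compounds alone, the groups of compound 2 and compound 3 could not be told apart, so this is the first sign that the group at this position can change the number. On these data alone, how a carboxylic acid, a methyl ester or a carboxamide with a longer chain on its nitrogen would compare here remains open. Nothing shown explains why carbamoyl gives the lower number.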